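The source may report more compounds than this note shows. Statements on the series, on what has been measured and on what is new or still open speak of the compounds shown alone.

Compound 2 `CC1(C)C=C(n2ccccc2=O)c2cc(S(=O)(=O)N3CCOCC3)ccc2O1` stands lowest of the two numbers measured in a functional assay with Rattus norvegicus as the target (a lower number here means that less compound is needed, a higher number that more compound is needed for the effect), where compound 2 gives 85.1 nM. Within the data shown here, its only measured neighbour, compound 1 `CC1(C)C=C(n2ccccc2=O)c2cc(S(=O)(=O)Nc3ccc([N+](=O)[O-])cc3)ccc2O1`, gives 2090 nM in this assay, and the one measured step is a 25-fold lower number from compound 1 to compound 2 (1.39 log units; beyond the scatter). Compound 3 `CC1(C)C=C(n2ccccc2=O)c2cc(S(=O)(=O)Oc3ccccc3)ccc2O1` differs from compound 2 by phenoxy in place of morpholin-4-yl on a sulfonyl sulfur. Because a 25-fold lower number from compound 1 to compound 2 (1.39 log units; beyond the scatter) was large when a group with a ring of carbon only gave way to morpholin-4-yl on this sulfonyl sulfur, returning to a ring of carbon only is expected to push the number back up, as a 7.1-fold higher number from compound 2 to compound 3 (0.85 log units; beyond the scatter). Compound 3 is therefore estimated at 600 nM in this assay, somewhere between 150 nM and 2500 nM.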

Compound 3, half-maximal effective concentration: 2.51 nM
Beside the measured number, compound 3's estimate is 240-fold (2.38 log units) above it; measured number outside the range, below it.
By their numbers in this assay, from the lowest: compound 3; then compound 2; then compound 1.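

In this assay, a ring of carbon only on this sulfonyl sulfur is no drawback in itself: a 34-fold lower number from compound 2 to compound 3 (1.53 log units; beyond the scatter) came with phenoxy replacing morpholin-4-yl. Phenoxy and (4-nitrophenyl)amino both carry such a ring, yet an 830-fold lower number from compound 1 to compound 3 (2.92 log units; beyond the scatter) shows that the ring alone does not set the number. Still open, as far as these compounds go, is whether the oxygen of phenoxy or the nitro group accounts for that gap, which a plain phenylamino group on the same sulfur would help to separate. Nothing available here explains these steps.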